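Swapping Ring Configuration at a Cytotoxicity Limit

A few compounds are considered here, and "the series" means these few. Any claim that something is new, unique, unknown or untested is made for them only; others in the source may bear on it.

Compound 1 `CN1CCC(CCn2c(N)nc3ccc(C(=O)c4ccccc4)cc32)CC1` in an ADME assay on CRL8155 cells (Homo sapiens) for cytotoxicity, read by resazurin assay, with a stated time of 72 h (on this read-out lower numbers stand for an effect already at smaller amounts and higher numbers for an effect only at larger amounts of compound), gives > 30000 nM, which is a limit of the assay and not a number.
Compound 2 `Nc1nc2ccc(C(=O)c3ccccc3)cc2n1C[C@H]1CCCN1` in this assay gives > 30000 nM, also a limit of the assay.

Compound 2 thus stands at the limit, where both measured values sit (the limit of > 30000 nM in this assay, at which 2 of the 2 values shown sit). The step that the two limits leave unreadable from compound 1 to compound 2 cannot be read from two limits. Compound 3 `Nc1nc2ccc(C(=O)c3ccccc3)cc2n1C[C@@H]1CCCN1` differs from compound 2 only in this way: the two compounds have the same atoms and bonds and differ only in configuration as drawn: 1 of 1 stereo elements differ; a stereocentre at a saturated ring carbon is drawn R in compound 2 and S in compound 3. Among the compounds with values here, no measured step bears on a change of configuration alone, so no movement beyond the scatter is expected. The expected step that the limit leaves unreadable from compound 2 to compound 3 is estimated as none beyond the scatter. Compound 3 is estimated at 40000 nM, within 20000 nM to 100000 nM.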

Compound 3, half-maximal effective concentration: > 30000 nM
Compound 3: only a limit was reported (the forecaster's own chance of this, stated with the estimate: 85%); the middle value is on the limit's open side.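

No step can be read from compound 1 or compound 2 to compound 3, since all three stand at a limit and not at a number: the limit of > 30000 nM in this assay, at which 3 of the 3 values shown sit. The compounds shown leave open how much compound is needed for an effect in this assay, and whether the configuration as drawn matters at all.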